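Benzyl variation on the triazole arm: compound 3 to compound 4

This account rests on a few compounds, and the source may have more. Where it says the series, first, only, none or still open, it means among the compounds named here.

In a functional assay on SW480 cells (Homo sapiens) for cytotoxicity, read by MTT assay, with a stated time of 48 h (on this read-out higher numbers stand for weaker inhibition and lower numbers for stronger inhibition), compound 1 `O=c1ccoc2cc(OCc3cn(Cc4ccc([N+](=O)[O-])cc4)nn3)ccc12` gives 19300 nM.
Compound 2 `O=c1ccoc2cc(OCc3cn(Cc4ccc(F)cc4)nn3)ccc12` gives 11200 nM.
Compound 3 `O=c1ccoc2cc(OCc3cn(Cc4cccc(Cl)c4)nn3)ccc12` gives 12900 nM.

Compound 3 stands second highest of the three numbers; its nearest neighbour is compound 2 (a 1.2-fold higher number from compound 2 to compound 3 (0.06 log units; within the scatter)), its furthest compound 1 (a 1.5-fold lower number from compound 1 to compound 3 (0.17 log units; within the scatter)). Compound 4 `O=c1ccoc2cc(OCc3cn(Cc4ccccc4F)nn3)ccc12` differs from compound 3 by 2-fluorophenyl in place of 3-chlorophenyl on a saturated chain carbon bound to an aromatic nitrogen. Every measured step in this series exchanges one substituted benzyl for another and stays within the scatter: a 1.7-fold lower number from compound 1 to compound 2 (0.24 log units; within the scatter), a 1.5-fold lower number from compound 1 to compound 3 (0.17 log units; within the scatter), a 1.2-fold higher number from compound 2 to compound 3 (0.06 log units; within the scatter). Nothing here indicates that the benzyl substituent moves the read-out beyond the scatter, so no step beyond it is expected for compound 4, meaning an expected 1.0-fold lower number from compound 3 to compound 4 (0.01 log units; within the scatter). Compound 4 is therefore estimated at 12500 nM, with a range from 6000 nM to 26000 nM in this assay.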

Compound 4, half-maximal inhibitory concentration: 11400 nM
Estimate against measurement, compound 4: 1.1-fold (0.04 log units) above; the measured number falls inside the stated range.
By their numbers in this assay, from the lowest: compounds 2, 4, 3 and 1 (each within the scatter of the next).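

Placing fluorine on the benzyl as 2-fluorophenyl, rather than 4-fluorophenyl, leaves the read-out in this assay within the scatter, with a 1.0-fold higher number from compound 2 to compound 4 (0.01 log units; within the scatter) as the first step in the series that keeps the halogen and changes only the name of the ring substituent. The other two steps also stay within the scatter: a 1.1-fold lower number from compound 3 to compound 4 (0.05 log units; within the scatter) and a 1.7-fold lower number from compound 1 to compound 4 (0.23 log units; within the scatter). No measurement at hand offers an explanation for this flat response.

Going by these compounds, whether a benzyl carrying an amine or a carboxylic acid would step beyond the scatter remains open. So does the effect of a longer chain in place of the benzyl.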